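A few compounds are considered here, and "the series" means these few. Any claim that something is new, unique, unknown or untested is made for them only; others in the source may bear on it.

Working notes on the series. In an assay on isolated protein for inhibition of Intestinal-type alkaline phosphatase (Bos taurus), read by chemiluminescence and spectrophotometry (on this read-out higher numbers stand for weaker inhibition and lower numbers for stronger inhibition), compound 1 `NS(=O)(=O)c1ccc(CNC(=O)c2ccccc2)cc1` gives 4450 nM. Compound 2 `NS(=O)(=O)c1ccc(NC(=O)c2ccc(F)cc2)cc1` gives 5910 nM in this assay. Compound 1 holds the lower of the two numbers, but the gap to compound 2 lies within the usual scatter, so the two values cannot be ordered and neither compound can be called the stronger inhibitor.

Compound 3 `NS(=O)(=O)c1ccc(CNC(=O)c2ccc(F)cc2)cc1` has not yet been measured in this assay. Against compound 1 the change is fluoro in place of hydrogen on an aromatic carbon, read one bond further out as phenyl to 4-fluorophenyl. Among the compounds with values here, no step between two measured compounds that differ in one place is available, so the size of this change has no anchor; the two measured values simply sit within scatter of each other.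

The step from compound 1 to compound 3 is expected to be a 1.1-fold lower number from compound 1 to compound 3 (0.05 log units; within the scatter), nothing beyond the scatter in either direction. Compound 3 is therefore estimated at 4000 nM in this assay, with an expected range from 1500 nM to 10000 nM.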

Compound 3, half-maximal inhibitory concentration: 1180 nM
Compound 3: the middle estimate sits 3.4-fold (0.53 log units) above what was measured; measured number below the stated range.
By their numbers in this assay, from the lowest: compound 3; then compounds 1 and 2 (each within the scatter of the next).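

In this assay, within the data shown here, the change from phenyl to 4-fluorophenyl gives a 3.8-fold lower number from compound 1 to compound 3 (0.58 log units; beyond the scatter), the first step between two compounds that differ in one place. It shows that this aromatic carbon, para to a large group, is not indifferent to substitution: a single fluoro in place of hydrogen moves the number beyond the scatter, something the earlier pair, compound 1 and compound 2, could not show, as those two differ in more than one place and sit within the scatter of each other. Nothing available bears on why the step has this size and direction.

From the compounds shown here alone, whether the step is particular to fluoro or would also follow from chloro, methyl or methoxy on the same aromatic carbon remains open. Also open is whether fluoro has a comparable effect on the core of compound 2, for which the compounds shown offer no partner carrying plain phenyl.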